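Added Chlorine in a Three-Compound Cytotoxicity Series

The compounds below may be only part of what the source reports. "The series", "measured", "known", "first", "only" and "open" are said of these compounds alone.

Compound 1 `CC(C)=CCC[C@@](C)(/C=C/c1ccccc1)/C=C/c1ccc(O)cc1`: > 43400 nM
Compound 2 `CC(C)=CCC[C@](C)(/C=C/c1ccc(O)cc1)/C=C/c1cccc(Cl)c1`: > 43400 nM
Compound 3 `C=C[C@@](C)(/C=C/c1ccc(Nc2ccc(Cl)cc2)cc1)CCC=C(C)C`: > 43400 nM

Three compounds were tested in a functional assay on NALM-6 cells (Homo sapiens) for cytotoxicity, with a stated time of 72 h; a lower number here means that less compound is needed, a higher number that more compound is needed for the effect. For compound 1 the value is a limit of the assay, > 43400 nM. For compound 2 the value is likewise a limit, > 43400 nM. For compound 3 the value is also a limit, > 43400 nM. The change from compound 1 to compound 2 is chloro in place of hydrogen on an aromatic carbon, and the step it made is a step that the two limits leave unreadable from compound 1 to compound 2. Compound 4 `C=C[C@@](C)(/C=C/c1ccc(Nc2ccc(Cl)c(Cl)c2)cc1)CCC=C(C)C` has not yet been measured; it differs from compound 3 by chloro in place of hydrogen on an aromatic carbon, the same kind of change as that from compound 1 to compound 2, but here the place is ortho to a chloro group and meta to a large group, whereas in compound 2 it is only meta to a large group. How the core of compound 3 differs from the core of compound 1 is not broken down here. All three measured values rest at the limit of > 43400 nM in this assay, at which 3 of the 3 values shown sit. Because compound 3 sits at > 43400 nM and the earlier step is unreadable, the step from compound 3 to compound 4 is expected to be about a step that the limit leaves unreadable from compound 3 to compound 4. Compound 4 is therefore estimated at 60000 nM, with a likely range from 20000 nM to 200000 nM.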

Compound 4, half-maximal effective concentration: > 43400 nM
Compound 4: only a limit was reported; the forecaster's own chance of this, stated with the estimate: 75%; the middle value lies beyond the limit too.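

Compound 3 and compound 4 both carry only a limit, so no step between them can be read, and the same holds for the step from compound 1 to compound 2: the limit of > 43400 nM in this assay, at which 4 of the 4 values shown sit.

The compounds shown leave open how far any of them lies beyond that limit, and so what either chloro in place of hydrogen does to the read-out.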